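The source may report more compounds than this note shows. Statements on the series, on what has been measured and on what is new or still open speak of the compounds shown alone.

Compound 1 `COc1ccc(C2N=C(SCc3ccccc3)NC(C)=C2C(=O)Nc2ccc(F)cc2)cc1OC`: 12.9%
Compound 2 `COc1ccc(C2N=C(SCc3ccc(Cl)cc3)NC(C)=C2C(=O)Nc2ccc(F)cc2)cc1OC`: 20.1%
Compound 3 `COc1ccc(C2N=C(SCc3ccc(F)cc3)NC(C)=C2C(=O)Nc2ccc(F)cc2)cc1OC`: 22.2%

These three numbers come from a functional assay on the whole organism (artery, strain albino) with Rattus norvegicus as the target, with a stated time of 180 min, at a dose of 10 mg/kg by the oral route; a higher number here means more inhibition at the dose given (going by the name of the read-out), a lower number less inhibition. Compound 1 stands lowest of the three. Its nearest neighbour is compound 2, a number 7.2 percentage points higher from compound 1 to compound 2 (within the scatter); the furthest is compound 3, a number 9.3 percentage points higher from compound 1 to compound 3 (within the scatter). Between the two halogen-bearing compounds the gap is a number 2.1 percentage points higher from compound 2 to compound 3 (within the scatter). All three compounds therefore sit together within the usual scatter, and no ordering among them can be read from the data.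

Compound 4 `CC1=C(C(=O)Nc2ccc(F)cc2)C(c2ccc([N+](=O)[O-])cc2)N=C(SCc2ccccc2)N1` has not yet been measured. It differs from compound 1 in one place: 4-nitrophenyl in place of 3,4-dimethoxyphenyl on a saturated ring carbon. Going by the values given here, the measured steps all swap hydrogen for chloro or fluoro on the aromatic ring of the benzylsulfanyl group; none of them touches the 3,4-dimethoxyphenyl group that is exchanged here, so no measured step bears directly on this change. With the three measured compounds all within scatter of one another, and nothing to suggest a larger movement, the expected step is a number 2.1 percentage points higher from compound 1 to compound 4 (within the scatter), meaning none beyond the scatter. Compound 4 is therefore estimated at 15%, with a range from 3% to 32%.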

Compound 4, a percentage reported as inhibition, in the whole organism at one dose (the size of the read-out at that dose, not a potency): 23.7%
Beside the measured number, compound 4's estimate is 8.7 percentage points below it; low and high end bracket the measured number.
By their numbers in this assay, from the lowest: compounds 1, 2, 3 and 4 (each within the scatter of the next, the first and the last beyond it).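

Exchanging 3,4-dimethoxyphenyl for 4-nitrophenyl on the saturated ring carbon gives, in this assay, a number 10.8 percentage points higher from compound 1 to compound 4 (beyond the scatter), the only step shown for compound 1 that lies beyond the scatter. This position can therefore shift the read-out, if only modestly, whereas the halogen swaps on the benzylsulfanyl ring did not do so beyond the scatter. Nothing available explains why this exchange gives more inhibition.

Compound 4 removes both methoxy groups and brings in the nitro group in a single step, and the compounds shown do not separate those two changes. Also open, from the compounds shown here alone, are how an amine or a carboxylic acid in place of the nitro group would read, and whether chloro or fluoro on the benzylsulfanyl ring would add to this step.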